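The source may report more compounds than this note shows. Statements on the series, on what has been measured and on what is new or still open speak of the compounds shown alone.

Among the compounds with values here, compound 2 `CCSc1nc(Nc2cccc(OC)c2)c2ccncc2n1` is the weaker of the two compounds measured so far: in a functional assay on HepG2 cells (Homo sapiens) for inhibition, read by MTT assay, with a stated time of 72 h (a higher number here means a weaker inhibitor, a lower number a stronger inhibitor), compound 2 gives 10700 nM, the highest of the two numbers in hand. Its nearest neighbour is compound 1 `C#CCSc1nc(Nc2cccc(OC)c2)c2ccncc2n1`, which in this assay gives 920 nM. Within the data shown here, the single step between them is a 12-fold higher number from compound 1 to compound 2 (1.07 log units; beyond the scatter), a large change that arises from a swap at the end of the chain attached to the sulfur.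

Compound 3 `CCCSc1nc(Nc2cccc(OC)c2)c2ccncc2n1` differs from compound 2 by methyl in place of hydrogen on a saturated chain carbon, two bonds along the chain from a sulfur. Among the measured compounds shown here, no measured step reproduces this exact change. For the measured compounds named here, the one step that bears on it, a 12-fold higher number from compound 1 to compound 2 (1.07 log units; beyond the scatter), concerns the same chain but exchanges a different group, so it offers only a loose guide: it shows that the chain on the sulfur matters to this assay, without showing what a further methyl on the chain does. On that basis a modest step is expected for this assay, most likely toward a somewhat lower number but possibly none beyond the scatter; the expected step is a 1.5-fold lower number from compound 2 to compound 3 (0.18 log units; within the scatter). Compound 3 is therefore estimated at 7000 nM, within a range from 2000 nM to 25000 nM.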

Compound 3, half-maximal inhibitory concentration: 17300 nM
Compound 3: the middle estimate sits 2.5-fold (0.39 log units) below what was measured; measured number inside the range.
By their numbers in this assay, from the lowest: compound 1; then compounds 2 and 3 (each within the scatter of the next).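

In this assay, methyl in place of hydrogen on a saturated chain carbon, two bonds along the chain from a sulfur, gives a 1.6-fold higher number from compound 2 to compound 3 (0.21 log units; within the scatter), so ethylsulfanyl and propylsulfanyl cannot be told apart here and this added carbon has no effect that can be read. The earlier step replaced ethynyl with methyl, and replacing ethynyl with ethyl instead yields a 19-fold higher number from compound 1 to compound 3 (1.27 log units; beyond the scatter), so compound 1 stands clearly apart from both compounds with a saturated chain. No measurement available here explains why the ethynyl compound differs from the two saturated ones.

The compounds shown leave open whether a longer chain such as butyl, or a branched one such as isopropyl, would also stay with compound 2 and compound 3. They also leave open whether the ethynyl group is special at the chain end, or whether an ethenyl, a nitrile, an amine or a carboxylic acid there would match compound 1.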